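The source may report more compounds than this note shows. Statements on the series, on what has been measured and on what is new or still open speak of the compounds shown alone.

Compound 1, `Cc1cccc(NC(=O)CCN2CCN(c3ccccn3)CC2)c1`, compound 2, `Cc1cccc(NC(=O)CCN2CCN(c3ncccn3)CC2)c1`, and compound 3, `Cc1cccc(NC(=O)CN2CCN(c3ncccn3)CC2)c1`, were all tested in an assay on HEK293 cells for displacement of a labelled ligand from D(4) dopamine receptor (Homo sapiens), read by scintillation counting, with a stated time of 60 min; a higher number here means a weaker inhibitor, a lower number a stronger inhibitor. In this assay compound 1 gives 297 nM, compound 2 gives 526 nM, and compound 3 gives 318 nM. Compound 1 and compound 2 differ in one place, (pyridin-2-yl in place of pyrimidin-2-yl on an amine nitrogen in a ring), and this change made a step of a 1.8-fold lower number from compound 2 to compound 1 (0.25 log units; within the scatter). Compound 3 and compound 2 share the same heteroaromatic group on the ring nitrogen, but the difference between their two cores is not broken down here; their values sit within the scatter of each other, as do those of compound 3 and compound 1.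

Compound 4, `Cc1cccc(NC(=O)CN2CCN(c3ccccn3)CC2)c1`, has not yet been measured. It differs from compound 3 by pyridin-2-yl in place of pyrimidin-2-yl on an amine nitrogen in a ring, the same change already seen from compound 2 to compound 1, at the same place. For the measured compounds named here, the step from compound 3 to compound 4 is therefore expected to be a 1.8-fold lower number from compound 3 to compound 4 (0.25 log units; within the scatter), close to the earlier one, because the only measured example of this change gave a 1.8-fold lower number from compound 2 to compound 1 (0.25 log units; within the scatter). On that basis compound 4 is estimated at 180 nM in this assay, with a plausible range from 90 nM to 360 nM.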

Compound 4, inhibition constant: 212 nM
For compound 4 the middle estimate is 1.2-fold (0.07 log units) below the measured one; low and high end bracket the measured number.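

On the core of compound 3, putting pyridin-2-yl in place of pyrimidin-2-yl gives a 1.5-fold lower number from compound 3 to compound 4 (0.18 log units; within the scatter) in this assay, and this step can be set beside the earlier one: the same change on two cores in this assay, a 1.8-fold lower number (0.25 log units; within the scatter) from compound 2 to compound 1 and a 1.5-fold lower number (0.18 log units; within the scatter) from compound 3 to compound 4, 1.2-fold (0.07 log units) apart, within the scatter of two such steps Within this small set, then, the change carries from the core of compound 1 to the core of compound 3 with no detectable difference in the size of its step. It does not show that the change truly lowers the number, as each step on its own lies within the scatter, and two cores are too few to support a rule for the whole series.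

The compounds shown leave open whether the same match would hold on a core with a longer chain linking the amide to the ring nitrogen, or with an amine or a carboxylic acid in place of the methyl group. They also leave open how a plain phenyl group on that ring nitrogen would compare with pyridin-2-yl and pyrimidin-2-yl.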